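Replacing a sulfonyl with a sulfanyl in compound 2

This account rests on a few compounds, and the source may have more. Where it says the series, first, only, none or still open, it means among the compounds named here.

Values measured so far in a functional assay on DU-145 cells (Homo sapiens) for inhibition, read by trypan blue exclusion, with a stated time of 96 h; a lower number here means a stronger inhibitor of growth, a higher number a weaker inhibitor of growth:
- Compound 1 `COc1ccc(/C=C(\C(=O)c2ccc(Br)cc2)S(=O)(=O)c2ccc(Br)cc2)cc1` gives 25000 nM
- Compound 2 `O=C(/C(=C\c1ccc(OC(F)(F)F)cc1)S(=O)(=O)c1ccc(Br)cc1)c1ccc(Br)cc1` gives 25000 nM

Among the measured compounds shown here, compound 2 stands level with compound 1, the only other compound measured. The next structure, compound 3 `O=C(/C(=C\c1ccc(OC(F)(F)F)cc1)Sc1ccc(Br)cc1)c1ccc(Br)cc1`, comes from compound 2 through a single change ((4-bromophenyl)sulfanyl in place of (4-bromophenyl)sulfonyl on a double-bonded chain carbon bound to a carbonyl carbon and a double-bonded chain carbon): (4-bromophenyl)sulfanyl in place of (4-bromophenyl)sulfonyl on a double-bonded chain carbon bound to a carbonyl carbon and a double-bonded chain carbon. For the measured compounds named here, the only measured step, no change at the digits printed from compound 1 to compound 2 (within the scatter), lies elsewhere in the molecule and says little about this change. Going by the values given here, no measured step involves this swap, so the data give no direction, and a large shift either way cannot be excluded. The best anchor is therefore compound 2 at 25000 nM and no step beyond the scatter is expected. The expected step is a 1.3-fold lower number from compound 2 to compound 3 (0.10 log units; within the scatter) in this estimate. In this assay compound 3 is expected at about 20000 nM with an estimated range from 5000 nM to 50000 nM as its span.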

Compound 3, concentration for 50% growth inhibition: 10000 nM
Beside the measured number, compound 3's estimate is 2.0-fold (0.30 log units) above it, and the stated range covers the measured number.
By their numbers in this assay, from the lowest: compound 3; then compounds 1 and 2 (each within the scatter of the next).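

In this assay, putting (4-bromophenyl)sulfanyl in place of (4-bromophenyl)sulfonyl on the double-bonded chain carbon gives a 2.5-fold lower number from compound 2 to compound 3 (0.40 log units; beyond the scatter) as the outcome, a modest gain in growth inhibition. Among the compounds shown here, the earlier step, no change at the digits printed from compound 1 to compound 2 (within the scatter) at the other end of the molecule, left the number unmoved, so this is the first place where a single change shifts the result beyond the scatter. It also shows that the sulfonyl oxygens are not required for this level of growth inhibition, although no measurement shown here explains the shift.

The compounds shown leave open how a sulfinyl group or a plain methylene link would behave at this place. They also leave open whether the same swap would give a similar step on the core of compound 1, which carries a methyl on the oxygen rather than a trifluoromethyl.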